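Adding Fluorine to the Benzyl Group of Compound 1

A few compounds are considered here, and "the series" means these few. Any claim that something is new, unique, unknown or untested is made for them only; others in the source may bear on it.

Compound 1, `CN(C)CCCCCSC1=Nc2ccccc2C(CC(=O)NCc2ccccc2)N1c1ccc(-c2ccc(F)cc2)cc1`, in an assay on cells for inhibition of Voltage-dependent T-type calcium channel subunit alpha-1H (Homo sapiens), read by patch clamp; on this read-out lower numbers stand for stronger inhibition and higher numbers for weaker inhibition: 4180 nM
Compound 2, `CN(C)CCCCCSC1=Nc2ccccc2C(CC(=O)NCc2ccccc2)N1c1ccccc1`, in this assay: 13800 nM

Among the compounds with values here, compound 1 holds the lowest of the two numbers measured so far. Within the data shown here, its only neighbour is compound 2, and the step between them is a 3.3-fold higher number from compound 1 to compound 2 (0.52 log units; beyond the scatter), brought about by hydrogen in place of 4-fluorophenyl on an aromatic carbon. That step concerns a different part of the shared core than the change now in question.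

Compound 3, `CN(C)CCCCCSC1=Nc2ccccc2C(CC(=O)NCc2ccc(F)cc2)N1c1ccc(-c2ccc(F)cc2)cc1`, awaits measurement. It differs from compound 1 by fluoro in place of hydrogen on an aromatic carbon, on an aromatic carbon of a six-membered aromatic ring of carbon only, para to a large group. Among the measured compounds shown here, no measured step touches the benzyl end of the amide, so nothing in the data points in either direction. Compound 3 is therefore expected to land close to compound 1, with a step of a 1.2-fold lower number from compound 1 to compound 3 (0.08 log units; within the scatter) that stays within the scatter. The estimate for compound 3 is 3500 nM, with a range from 1400 nM to 9000 nM.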

Compound 3, half-maximal inhibitory concentration: 2760 nM
Compound 3: the middle estimate sits 1.3-fold (0.10 log units) above what was measured; low and high end bracket the measured number.
By their numbers in this assay, from the lowest: compounds 3 and 1 (each within the scatter of the next); then compound 2.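

Within the data shown here, this is the first reading at the benzyl end of the amide: in this assay, fluoro in place of hydrogen on an aromatic carbon, para to a large group, gives a 1.5-fold lower number from compound 1 to compound 3 (0.18 log units; within the scatter). The position therefore accepts 4-fluorobenzyl without a difference that the measurement can separate, whereas the change at the other end of the molecule, a 3.3-fold higher number from compound 1 to compound 2 (0.52 log units; beyond the scatter), lies beyond the scatter. No evidence at hand bears on this outcome.

From the compounds shown here alone, whether this end of the molecule responds at all remains open, as one fluoro says nothing about a methoxy group, a trifluoromethyl group or a carboxylic acid at the same place, or about a longer chain in place of the benzyl group. Also open, going by these compounds, is whether fluoro would read the same on compound 2, which lacks the 4-fluorophenyl group.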